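Methyl for bromo where cytotoxicity has so far stayed at the limit

This account rests on a few compounds, and the source may have more. Where it says the series, first, only, none or still open, it means among the compounds named here.

Compound 1, `COC(=O)c1cc(-c2cccc(NC(=O)c3ccc(/C=C/C(=O)c4cccs4)cc3)c2)on1`, in an ADME assay on Vero cells (Chlorocebus sabaeus) for cytotoxicity, read by MTT assay, with a stated time of 72 h (a higher number here means that more compound is tolerated, a lower number that less compound is tolerated), gave "not determined" (no result reported).
Compound 2, `COC(=O)c1cc(-c2cccc(NC(=O)c3ccc(/C=C/C(=O)c4cc(F)ccc4F)cc3)c2)on1`, gave only a limit, > 40 ug/mL.
Compound 3, `COC(=O)c1cc(-c2cccc(NC(=O)c3ccc(/C=C/C(=O)c4ccccc4Br)cc3)c2)on1`, likewise gave only a limit, > 40 ug/mL.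

Compound 3 therefore stands at the limit of > 40 ug/mL in this assay, at which 2 of the 3 values shown sit, with no single number for any compound. Among the compounds with values here, the only comparable step, a step that the two limits leave unreadable from compound 2 to compound 3, cannot be sized for the same reason. Compound 4, `COC(=O)c1cc(-c2cccc(NC(=O)c3ccc(/C=C/C(=O)c4ccccc4C)cc3)c2)on1`, differs from compound 3 by methyl in place of bromo on an aromatic carbon. Within the data shown here, no measured step bears on this change, so no shift beyond the scatter is expected in this assay, and compound 4 is expected to give 45 ug/mL, between 25 ug/mL and 90 ug/mL, most likely again as a limit. The step this estimate implies is a step that the limit leaves unreadable from compound 3 to compound 4.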

Compound 4, half-maximal cytotoxic concentration: > 25 ug/mL
Compound 4 was reported as a limit (the forecaster's own chance of this, stated with the estimate: 75%); the middle value lies beyond the limit too.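

Within the data shown here, compound 2, compound 3 and compound 4 all stand only as limits in this assay, and no step among them can be read. Still open, as far as these compounds go, is the concentration at which any of them harms the cells, and whether methyl in place of bromo shifts it.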